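Dropping the Methoxy Group from Compound 1

The compounds below may be only part of what the source reports. "The series", "measured", "known", "first", "only" and "open" are said of these compounds alone.

Compound 1, `COc1ccc2occ(CSC(=S)N3CCCCC3)c(=O)c2c1`, gives 4700 nM in a functional assay on LM7 cells (Homo sapiens) for antiproliferative activity, read by MTT assay, with a stated time of 72 h; a higher number here means a weaker inhibitor, a lower number a stronger inhibitor.
Compound 2, `COc1ccc2occ(CSC(=S)N3CCCC3)c(=O)c2c1`, gives 6000 nM in this assay.

Compound 1 stands at the lower number of the two, but its step to compound 2, a 1.3-fold higher number from compound 1 to compound 2 (0.11 log units; within the scatter), lies within the scatter, so the two are not told apart. Compound 3, `O=c1c(CSC(=S)N2CCCCC2)coc2ccccc12`, differs from compound 1 by hydrogen in place of methoxy on an aromatic carbon. Within the data shown here, the single measured step swaps the ring on the thiocarbonyl carbon and leaves the methoxy untouched, so no measured step bears on this change. Lacking any guide, compound 3 is expected to stay close to compound 1, with the step of a 1.1-fold higher number from compound 1 to compound 3 (0.03 log units; within the scatter) within the scatter. The estimate for compound 3 in this assay is 5000 nM, ranging from 1800 nM to 14000 nM.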

Compound 3, half-maximal inhibitory concentration: 4600 nM
Compound 3: the middle estimate sits 1.1-fold (0.04 log units) above what was measured; measured number inside the range.
By their numbers in this assay, from the lowest: compounds 3, 1 and 2 (each within the scatter of the next).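

Hydrogen in place of methoxy on this aromatic carbon gives a 1.0-fold lower number from compound 1 to compound 3 (0.01 log units; within the scatter) in this assay, so compound 1 and compound 3 cannot be told apart. With piperidin-1-yl on the thiocarbonyl carbon, then, the methoxy group is not needed to keep this level of antiproliferative activity. No evidence is available to explain this result.

Still open, on these data alone, is whether a chlorine, an amine or a longer ethoxy chain at this carbon would shift the number. Also open, as far as these compounds go, is whether hydrogen in place of methoxy behaves the same way with the pyrrolidin-1-yl ring of compound 2.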